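The source may report more compounds than this note shows. Statements on the series, on what has been measured and on what is new or still open speak of the compounds shown alone.

Measured compounds:
compound 1 `c1ccc(CN(CCCCN(C[C@H]2Cc3ccccc3CN2)[C@H]2CCCc3cccnc32)Cc2ccccc2)cc1` in a functional assay on cells for agonist activity at C-X-C chemokine receptor type 4 (Homo sapiens), read by fluorescence and calcium flux, with a stated time of 90 s; on this read-out lower numbers stand for an effect already at smaller amounts and higher numbers for an effect only at larger amounts of compound — > 30000 nM, a limit of the assay.
compound 2 `c1ccc(CNCCCCN(C[C@H]2Cc3ccccc3CN2)[C@H]2CCCc3cccnc32)cc1` in this assay — > 30000 nM, a limit of the assay.

Compound 2 therefore stands at the limit rather than at a number, and this is the case for both values shown (the limit of > 30000 nM in this assay, at which 2 of the 2 values shown sit). The step that the two limits leave unreadable from compound 1 to compound 2, in which hydrogen replaces a benzyl on an amine nitrogen, cannot be read in size because both ends are limits.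

Compound 3 `O=S1(=O)CCC(CNCCCCN(C[C@H]2Cc3ccccc3CN2)[C@H]2CCCc3cccnc32)CC1` differs from compound 2 by 1,1-dioxothian-4-yl in place of phenyl on a saturated chain carbon bound to an amine nitrogen. Going by the values given here, no measured step bears directly on this change, and the one measured step gives no readable size. With compound 2 at the limit, compound 3 is expected to stay at or near the limit as well, so the estimated step of a number no higher from compound 2 to compound 3 (the limit leaves the size open) is none beyond the scatter. The estimated value for compound 3 in this assay is 30000 nM, within 8000 nM to 100000 nM.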

Compound 3, half-maximal effective concentration: > 30000 nM
Compound 3: no number, only a limit (the forecaster's own chance of this, stated with the estimate: 85%); the middle value sits exactly at the limit.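

Compound 3 also gives only a limit, so the change from compound 2 to compound 3 has no readable size, and no new step can be read: the limit of > 30000 nM in this assay, at which 3 of the 3 values shown sit. The compounds shown leave open whether benzyl or (1,1-dioxothian-4-yl)methyl on that amine nitrogen makes any difference to the calcium signal.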